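This account rests on a few compounds, and the source may have more. Where it says the series, first, only, none or still open, it means among the compounds named here.

Measured so far in a functional assay on MCF7 cells (Homo sapiens) for antiproliferative activity, read by MTT assay, with a stated time of 72 h; on this read-out lower numbers stand for stronger inhibition and higher numbers for weaker inhibition: compound 1 `C=CC(=O)Nc1cc2c(N3CCc4ccccc43)ncnc2cc1OC` gives 11700 nM; compound 2 `C=CC(=O)Nc1cc2c(N3CCc4ccccc43)ncnc2cc1O[C@@H]1CCOC1` gives 5950 nM; compound 3 `COc1cc2ncnc(N3CCc4ccccc43)c2cc1NC(=O)/C=C/CN1CCCC1` gives 1510 nM.

Compound 2 stands second highest of the three numbers. Its nearest neighbour is compound 1, with a 2.0-fold lower number from compound 1 to compound 2 (0.29 log units; within the scatter); its furthest is compound 3, whose number is lower by a margin beyond the scatter.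

Compound 4 `O=C(/C=C/CN1CCC(CO)CC1)Nc1cc2c(N3CCc4ccccc43)ncnc2cc1O[C@@H]1CCOC1` arises from compound 2 by 3-(4-(hydroxymethyl)piperidin-1-yl)prop-1-en-1-yl in place of vinyl on a carbonyl carbon. Among the compounds with values here, the one measured step that bears on this is a 7.7-fold lower number from compound 1 to compound 3 (0.89 log units; beyond the scatter), where 3-(pyrrolidin-1-yl)prop-1-en-1-yl replaced vinyl on the same carbonyl carbon. A step of comparable size toward a lower number in this assay is therefore expected, estimated as a 6.6-fold lower number from compound 2 to compound 4 (0.82 log units; beyond the scatter). Compound 4 is expected to give 900 nM, with a range from 300 nM to 2700 nM.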

Compound 4, half-maximal inhibitory concentration: 4690 nM
Compound 4: the middle estimate sits 5.2-fold (0.72 log units) below what was measured; measured number above the stated range.
By their numbers in this assay, from the lowest: compound 3; then compounds 4, 2 and 1 (each within the scatter of the next, the first and the last beyond it).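

In this assay, the 3-(4-(hydroxymethyl)piperidin-1-yl)prop-1-en-1-yl group on the carbonyl carbon gives only a 1.3-fold lower number from compound 2 to compound 4 (0.10 log units; within the scatter). The earlier step with 3-(pyrrolidin-1-yl)prop-1-en-1-yl, a 7.7-fold lower number from compound 1 to compound 3 (0.89 log units; beyond the scatter), was therefore not a general result of extending the group at this position, at least when the oxygen carries oxolan-3-yl. No measurement given here accounts for the difference between the two steps.

From the compounds shown here alone, it remains open whether the amine ring or the group on the oxygen sets the size of the step. Going by these compounds, how a morpholin-4-yl or dimethylamino group at the end of the same chain would read also remains open.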